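The compounds below may be only part of what the source reports. "The series", "measured", "known", "first", "only" and "open" are said of these compounds alone.

Measured compounds:
compound 1, `O=C(Nc1cccc(-c2oc3cc(-c4ccc(F)cc4)ccc3c(=O)c2O)c1)c1ccccc1F`: 7240 nM
compound 2, `O=C(Nc1cccc(-c2oc3cc(-c4ccc(F)cc4)ccc3c(=O)c2O)c1)c1ccc(C(F)(F)F)cc1`: 29400 nM

In a functional assay on MDA-MB-231 cells (Homo sapiens) for antiproliferative activity, read by CCK-8 assay, with a stated time of 72 h (on this read-out lower numbers stand for stronger inhibition and higher numbers for weaker inhibition), compound 2 gives the highest of the two numbers recorded; its nearest neighbour is compound 1, and the step of a 4.1-fold higher number from compound 1 to compound 2 (0.61 log units; beyond the scatter) lies beyond the scatter, so compound 2 is the weaker of the two. Compound 3, `O=C(Nc1cccc(-c2oc3cc(-c4ccc(F)cc4)ccc3c(=O)c2O)c1)c1cc(F)cc(F)c1`, has not yet been measured. It differs from compound 2 in a single place: 3,5-difluorophenyl in place of 4-(trifluoromethyl)phenyl on a carbonyl carbon. Within the data shown here, the only measured step that bears on this change is the one from compound 1 to compound 2, a 4.1-fold higher number from compound 1 to compound 2 (0.61 log units; beyond the scatter), in which a fluorinated phenyl with a single fluorine was exchanged for the 4-(trifluoromethyl)phenyl. Compound 3 returns to a phenyl bearing fluorine atoms, so a lower number than that of compound 2 is expected, a 2.9-fold lower number from compound 2 to compound 3 (0.47 log units; beyond the scatter), though the exact extent is uncertain on two points. Compound 3 is estimated at 10000 nM, with a range from 4000 nM to 25000 nM.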

Compound 3, half-maximal inhibitory concentration: 2440 nM
The estimate for compound 3 lay 4.1-fold (0.61 log units) above the measured number; measured number below the stated range.
By their numbers in this assay, from the lowest: compound 3; then compound 1; then compound 2.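

In this series, the group on the carbonyl carbon matters more than the earlier pair could show: the 3,5-difluorophenyl group gives a 12-fold lower number from compound 2 to compound 3 (1.08 log units; beyond the scatter) in this assay and thus a large change at this one place. It also gives a 3.0-fold lower number from compound 1 to compound 3 (0.47 log units; beyond the scatter) so the exchange does more than restore the level seen with the 2-fluorophenyl group. All three steps among these fluorinated groups lie beyond the scatter, so the position clearly separates them, though three compounds establish no general trend.

No measurement shown explains these differences.

On these data alone, whether an unsubstituted phenyl, or a phenyl carrying a methoxy group or an amine, would fall within the same range on this carbonyl carbon remains open. Also open, as far as these compounds go, is whether this order would hold outside this assay in any other cell line.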